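From Acetyl to Propanoyl on the Shared Core

A few compounds are considered here, and "the series" means these few. Any claim that something is new, unique, unknown or untested is made for them only; others in the source may bear on it.

In an assay on Sf9 cells for inhibition of mitogen-activated protein kinase kinase kinase 14 (Homo sapiens), read by ADP-Glo, with a stated time of 60 min (on this read-out lower numbers stand for stronger inhibition and higher numbers for weaker inhibition), compound 1 `Cc1ccc(-c2c(N)n[nH]c2C)cc1C` reaches only a limit of the assay, > 100000 nM. Compound 2 `Cc1[nH]nc(N)c1-c1cccc(Cl)c1` likewise gives a limit there, > 100000 nM. Compound 3 `CC(=O)n1nc(C)c(-c2ccc(Cl)c(Cl)c2)c1N` is the one compound with a measured number, 8400 nM, and so it stands alone on the numbers shown. For compound 1 and compound 2 the read-out stops at the limit of > 100000 nM in this assay, at which 2 of the 3 values shown sit. Compound 4 `CCC(=O)n1nc(C)c(-c2ccc(Cl)c(Cl)c2)c1N` differs from compound 3 by methyl in place of hydrogen on a saturated chain carbon bound to a carbonyl carbon. Among the compounds with values here, no measured pair differs by such a change, so no step of this kind has been seen; the step is expected to stay within the usual scatter, in either direction. Compound 4 is therefore expected to give about 7000 nM, between 2500 nM and 20000 nM, which means an expected step of a 1.2-fold lower number from compound 3 to compound 4 (0.08 log units; within the scatter).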

Compound 4, half-maximal inhibitory concentration: 27400 nM
Compound 4: the middle estimate sits 3.9-fold (0.59 log units) below what was measured, outside the stated range (above it).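

This is the only step shown between two measured compounds that differ in one place, and it shows that this position responds to a single added carbon: changing acetyl to propanoyl gives a 3.3-fold higher number from compound 3 to compound 4 (0.51 log units; beyond the scatter). The added methyl, on a saturated chain carbon bound to a carbonyl carbon, therefore weakens inhibition in this assay by more than the usual scatter. Nothing shown accounts for this step.

One step cannot show how a longer chain such as butanoyl would behave. Nor does it show how an amine on the carbonyl carbon, in place of the chain, would fare.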